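Sulfanyl substituent notes on the shared core

The compounds below may be only part of what the source reports. "The series", "measured", "known", "first", "only" and "open" are said of these compounds alone.

Measured in a functional assay on BGC-823 cells (Homo sapiens) for inhibition, read by MTT assay, with a stated time of 72 h; on this read-out higher numbers stand for weaker inhibition and lower numbers for stronger inhibition:

compound 1 `Cc1cc(N2CC[C@@H](C)[C@@H](N(C)c3ncnc4[nH]ccc34)C2)n2nc(SCc3ccc(C(F)(F)F)cc3)nc2n1` gives 23300 nM
compound 2 `Cc1cc(N2CC[C@@H](C)[C@@H](N(C)c3ncnc4[nH]ccc34)C2)n2nc(SCC3CC3)nc2n1` gives 36500 nM
compound 3 `Cc1cc(N2CC[C@@H](C)[C@@H](N(C)c3ncnc4[nH]ccc34)C2)n2nc(SCc3ccccc3)nc2n1` gives 14400 nM

Compound 2 stands at the highest of the three numbers. Going by the values given here, its separation from compound 1, a 1.6-fold higher number from compound 1 to compound 2 (0.19 log units; within the scatter), is within the scatter and so carries no order; the one step that is beyond the scatter is a 2.5-fold lower number from compound 2 to compound 3 (0.40 log units; beyond the scatter), a modest one. The remaining step, a 1.6-fold lower number from compound 1 to compound 3 (0.21 log units; within the scatter), is also within the scatter.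

Compound 4 `Cc1cc(N2CC[C@@H](C)[C@@H](N(C)c3ncnc4[nH]ccc34)C2)n2nc(SCCCc3ccccc3)nc2n1` differs from compound 2 by phenethyl in place of cyclopropyl on a saturated chain carbon bound to a sulfur.

The step that bears most directly on this change is a 2.5-fold lower number from compound 2 to compound 3 (0.40 log units; beyond the scatter), where the cyclopropyl was likewise exchanged for an aromatic carbon ring on the same saturated chain carbon bound to a sulfur and the number fell modestly. Among the compounds with values here, compound 4 carries the phenyl on a longer chain than compound 3 does, and no measured compound tells how chain length matters here, so the expectation rests on the cyclopropyl-to-aryl exchange alone. A modest fall from compound 2, of about the size seen toward compound 3, is expected, with a wide range to cover the untested chain.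

Compound 4 is therefore expected to give 15000 nM, between 6000 nM and 40000 nM, which means a step of a 2.4-fold lower number from compound 2 to compound 4 (0.39 log units; beyond the scatter).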

Compound 4, half-maximal inhibitory concentration: > 100000 nM
Compound 4: a limit, no number; the forecaster's own chance of this, stated with the estimate: 5%; middle value at least 6.6-fold (0.82 log units) away from the limit.
By their numbers in this assay, from the lowest: compounds 3, 1 and 2 (each within the scatter of the next, the first and the last beyond it). At a limit, above all of these: compound 4.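

In this assay compound 4 stands at a limit of the assay and not at a number, > 100000 nM, and the reading has to be taken as such: the limit of > 100000 nM in this assay, at which 1 of the 4 values shown sits.

Among the earlier compounds this place, on a saturated chain carbon bound to a sulfur, produced no more than a modest separation, whereas 3-phenylpropyl now gives an at least 2.7-fold higher number from compound 2 to compound 4 (0.43 log units; beyond the scatter) and an at least 4.2-fold higher number from compound 1 to compound 4 (0.63 log units; beyond the scatter). The step that bears most directly on the chain is an at least 6.9-fold higher number from compound 3 to compound 4 (0.84 log units; beyond the scatter), where the phenyl ring stays and only the chain to the sulfur is longer, so an aromatic ring on this chain does not by itself go with the lower number, and chain length counts at this place.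

Going by these compounds, the true size of all three steps stays open, since each one ends at a limit. Also open, on these data alone, is how a 2-phenylethyl chain would read, or a chain carrying an amine or a carboxylic acid in place of the phenyl, and so whether the rise follows chain length in a graded way or appears abruptly.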